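The source may report more compounds than this note shows. Statements on the series, on what has been measured and on what is new or still open speak of the compounds shown alone.

Values measured in an ADME assay on the whole organism (plasma, Rattus norvegicus) for pharmacokinetics, read by LC-MS, at a dose of 0.1 mg/kg by the intravenous route; a lower number here means slower removal, a higher number faster removal of the compound
compound 1 `Cc1cnc(Oc2cc(Cl)c(F)c(-c3ccc4c(c3)CC[C@H](CCC(=O)O)O4)c2)s1` gives 1.6 mL/min/kg
compound 2 `O=C(O)CC[C@H]1CCc2cc(-c3cc(OC4CCC4)cc(F)c3F)ccc2O1` gives 5.4 mL/min/kg
compound 3 `O=C(O)CC[C@H]1CCc2cc(-c3nc(OC4CCC4)ccc3F)ccc2O1` gives 9.1 mL/min/kg

Among these three, compound 1 stands lowest, and compound 2 and compound 3 both lie above it by more than the usual scatter. Compound 4 `COc1cc(Oc2ncc(C)s2)cc(-c2ccc3c(c2)CC[C@H](CCC(=O)O)O3)c1F` has not yet been measured. It differs from compound 1 in one place (methoxy in place of chloro on an aromatic carbon), with methoxy in place of chloro on an aromatic carbon, ortho to a fluoro group. Among the measured compounds shown here, no pair of measured compounds shows this swap alone, so the data give no direct guide to its size. Compound 1 at 1.6 mL/min/kg already sits at the low end of the three numbers, so a move upward seems more likely than a move downward. The expected change is small, with a 1.8-fold higher number from compound 1 to compound 4 (0.24 log units; within the scatter) as the estimate, and it may not clear the usual scatter in this assay once measured. For compound 4 the estimated clearance is 2.8 mL/min/kg with an expected range from 1.3 mL/min/kg to 6 mL/min/kg in this rat study.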

Compound 4, clearance: 1.6 mL/min/kg
For compound 4 the middle estimate is 1.8-fold (0.24 log units) above the measured one, within the range that was stated.
By their numbers in this assay, from the lowest: compounds 1 and 4 (each within the scatter of the next); then compounds 2 and 3 (each within the scatter of the next).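

Placing methoxy in place of chloro on this aromatic carbon, ortho to a fluoro group, gives no change at the digits printed from compound 1 to compound 4 (within the scatter) in this assay. Among the compounds shown here, no earlier pair isolated a single change, so this is the first direct reading at this position: here, the swap adds one heavy atom and a hydrogen-bond acceptor with no change that can be told from the scatter. Nothing available explains why the two compounds read alike.

Still open, as far as these compounds go, is whether this position would accept very different groups, such as an amine or a nitrile, with the same result. It is also unknown whether methoxy in place of chloro would behave this way in a compound with a different group from the (5-methyl-1,3-thiazol-2-yl)oxy group.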